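The compounds below may be only part of what the source reports. "The series", "measured", "known", "first", "only" and "open" are said of these compounds alone.

In an assay on isolated protein for binding affinity to 5-hydroxytryptamine receptor 5A (Homo sapiens) (a lower number here means a stronger inhibitor, a higher number a weaker inhibitor), compound 2 `CNCc1ccc(Cl)c(-c2ccccc2OC)c1` gives 420 nM, the lowest of the two numbers recorded so far. For the measured compounds named here, its nearest neighbour is compound 1 `COc1ccccc1-c1cc(C2CCNC2)ccc1Cl`, which in this assay gives 970 nM; the one measured step, a 2.3-fold lower number from compound 1 to compound 2 (0.36 log units; beyond the scatter), exchanges pyrrolidin-3-yl for (methylamino)methyl on the aromatic carbon and is modest but beyond the scatter.

Compound 3 `CCNCc1ccc(Cl)c(-c2ccccc2OC)c1` differs from compound 2 by methyl in place of hydrogen on a saturated chain carbon bound to an amine nitrogen, so the amine end of the chain grows from methylamino to ethylamino. Going by the values given here, no measured step touches this change directly; the step from compound 1 to compound 2 concerns a different rearrangement of the same basic region and only shows that the amine portion can shift the number by a modest amount. With nothing pointing to a gain or a loss from one added carbon on the amine, a step within the scatter is expected, a 1.2-fold higher number from compound 2 to compound 3 (0.09 log units; within the scatter), if anything slightly toward a higher number.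

Compound 3 is therefore estimated at 520 nM in this assay, within a range from 200 nM to 1400 nM.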

Compound 3, inhibition constant: 1800 nM
Compound 3: middle estimate off by 3.5-fold (0.54 log units), on the low side; the measured number lies above the stated range.
By their numbers in this assay, from the lowest: compound 2; then compounds 1 and 3 (each within the scatter of the next).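

For the compounds shown here, with the shared core held constant, this is the first measured change confined to the amine end of the chain, and in this assay the added methyl matters: going from methylamino to ethylamino gives a 4.3-fold higher number from compound 2 to compound 3 (0.63 log units; beyond the scatter). The earlier advantage of the open chain over the ring therefore depends on what sits on the nitrogen, since (ethylamino)methyl in place of pyrrolidin-3-yl gives a 1.9-fold higher number from compound 1 to compound 3 (0.27 log units; within the scatter), whereas among these compounds only the (methylamino)methyl chain of compound 2 stands clear of compound 1 by more than the scatter. No available evidence accounts for the sensitivity of this position to the added methyl.

The compounds shown do not tell whether the number would keep rising along a longer chain such as propylamino, or how a branched isopropylamino group would compare. They also leave open how an unsubstituted aminomethyl group or a dimethylamino end would behave in this assay, and so whether methylamino is the best choice at this position or simply the better of the two chains shown.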